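The source may hold more compounds than are shown below. What is called first, only, known or untested is meant among the compounds shown, and "the series" means these compounds.

One small change in a series of compounds tested in a functional assay on HCT-15 cells (Homo sapiens) for cytotoxicity, read by MTT assay, with a stated time of 2 days (on this read-out lower numbers stand for stronger inhibition and higher numbers for weaker inhibition), is followed here. Compound 1, `Cc1ccc2c(=O)[nH]c(-c3ccccc3N(C)C)nc2c1`, is the starting point. In this assay, for the measured compounds named here, compound 1 gives 12800 nM, and this is the only number known in the set. The other two results are not numbers. Compound 2, `Cc1ccc2c(=O)[nH]c(-c3cccc(OC(F)(F)F)c3)nc2c1`, gives > 50000 nM, which is a limit of the assay and not a number. Compound 3, `Cc1ccc2nc(-c3ccccc3C(F)(F)F)[nH]c(=O)c2c1`, gives > 50000 nM, again a limit. Going by the values given here, two of the three results thus sit at the limit of > 50000 nM in this assay, at which 2 of the 3 values shown sit, so compound 1 stands alone as the one compound whose inhibition was measured as a number.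

Compound 4, `Cc1ccc2c(=O)[nH]c(-c3ccccc3C)nc2c1`, has not yet been tested. It differs from compound 1 in one place: methyl in place of dimethylamino on an aromatic carbon. Among the compounds with values here, no pair of measured compounds differing in a single place is known here, so the data give no direct guide to how a change of this kind moves the result.

The expected shift is a 2.0-fold higher number from compound 1 to compound 4 (0.29 log units; within the scatter), a modest loss of potency that may reach beyond the usual scatter, though a result within it would not surprise. For compound 4 the estimated value in this assay is 25000 nM, within a range from 8000 nM to 60000 nM, with a real chance that only a limit is reported.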

Compound 4, half-maximal inhibitory concentration: 11900 nM
The estimate for compound 4 lay 2.1-fold (0.32 log units) above the measured number, and the stated range covers the measured number.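

In this assay, putting methyl in place of dimethylamino on this aromatic carbon gives a 1.1-fold lower number from compound 1 to compound 4 (0.03 log units; within the scatter). For the compounds shown here, this is the first step in the set that can be read between two compounds differing in one place, and it shows that the two compounds cannot be told apart in this test. Compound 4 has no nitrogen in this group and still gives a number, so a measurable result here does not depend on the dimethylamino nitrogen, at least when methyl takes its place.

Compound 2 and compound 3 differ from compound 1 in more than one place, so they cannot be compared with it directly, and their results remain limits and not numbers: the limit of > 50000 nM in this assay, at which 2 of the 4 values shown sit.

Going by these compounds, whether a hydroxyl group, a carboxylic acid or a longer chain on this same aromatic carbon would move the result beyond the usual scatter stays open, as does the question of whether this position responds to any change at all.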